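Swapping fluoro for chloro on the urea phenyl ring

The source may hold more compounds than are shown below. What is called first, only, known or untested is meant among the compounds shown, and "the series" means these compounds.

Compound 1 `CN(C)CCNc1nc(-c2ccc(NC(=O)Nc3ccc(F)cc3)cc2)nc2c(Cl)c(Cl)sc12` carries a urea bridge to a fluorinated phenyl ring and a dimethylamino tail. In a functional assay on MKN-45 cells (Homo sapiens) for cytotoxicity, read by MTT assay, with a stated time of 72 h (on this read-out higher numbers stand for weaker inhibition and lower numbers for stronger inhibition), compound 1 gives 1350 nM. Compound 2 `CN(C)CCNc1nc(-c2ccc(NC(=O)Nc3ccc(Cl)cc3)cc2)nc2c(Cl)c(Cl)sc12` differs in one place: chloro in place of fluoro on an aromatic carbon. In this assay compound 2 gives 910 nM, a step of a 1.5-fold lower number from compound 1 to compound 2 (0.17 log units; within the scatter).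

Compound 3 `CCN(CC)CCCNc1nc(-c2ccc(NC(=O)Nc3ccc(F)cc3)cc2)nc2c(Cl)c(Cl)sc12` has a different core from compound 1; the two cores differ as follows: (diethylamino)methyl in place of dimethylamino on a saturated chain carbon, two bonds along the chain from a nitrogen on an aromatic ring. In this assay compound 3 gives 1700 nM, so that a 1.3-fold higher number from compound 1 to compound 3 (0.10 log units; within the scatter).

Compound 4 `CCN(CC)CCCNc1nc(-c2ccc(NC(=O)Nc3ccc(Cl)cc3)cc2)nc2c(Cl)c(Cl)sc12` is not yet measured. It differs from compound 3 in this way: chloro in place of fluoro on an aromatic carbon. The place is the same, word for word, as in the change from compound 1 to compound 2, so this is the same change made on the core of compound 3. Because the earlier step was a 1.5-fold lower number from compound 1 to compound 2 (0.17 log units; within the scatter), the expectation for compound 4 is a step of a 1.5-fold lower number from compound 3 to compound 4 (0.17 log units; within the scatter). Compound 4 is therefore estimated at 1150 nM. For compound 4 the expected range runs from 500 nM to 2600 nM, since a single earlier example inside the scatter leaves the direction of the step uncertain.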

Compound 4, half-maximal inhibitory concentration: 720 nM
Beside the measured number, compound 4's estimate is 1.6-fold (0.20 log units) above it; low and high end bracket the measured number.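

Chloro in place of fluoro on the core of compound 3 gives a 2.4-fold lower number from compound 3 to compound 4 (0.37 log units; beyond the scatter) in this assay, and the gap between this step and the earlier one is no larger than two such steps can show by chance: the same change on two cores in this assay, a 1.5-fold lower number (0.17 log units; within the scatter) from compound 1 to compound 2 and a 2.4-fold lower number (0.37 log units; beyond the scatter) from compound 3 to compound 4, 1.6-fold (0.20 log units) apart, within the scatter of two such steps

Exchanging the tail on the chloro compounds gives a 1.3-fold lower number from compound 2 to compound 4 (0.10 log units; within the scatter), and the two readings of that tail change also agree: the same change on two cores in this assay, a 1.3-fold higher number (0.10 log units; within the scatter) from compound 1 to compound 3 and a 1.3-fold lower number (0.10 log units; within the scatter) from compound 2 to compound 4, 1.6-fold (0.20 log units) apart, within the scatter of two such steps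

So the data fit the idea that each change carries from one core to the other, but they rest on only two cores, and just one of the four steps, the one ending at compound 4, lies beyond the scatter, so they show neither a firm size for the halogen step nor that it would hold on a further core.

The compounds shown leave open how a bromo or a methoxy group would read in the same place on the phenyl ring. They also leave open whether a morpholine or a longer chain at the tail would fit the same picture.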